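Replacing trifluoromethyl with benzoyl: solubility expectation

A few compounds are considered here, and "the series" means these few. Any claim that something is new, unique, unknown or untested is made for them only; others in the source may bear on it.

Measured compounds:
Compound 1, `O=C(c1ccccc1)c1ccc(NC(=O)c2cc(Cl)ccc2O)cc1`, in a physicochemical assay for solubility, read by spectrophotometry (a lower number here means a less soluble compound, a higher number a more soluble compound), gives < 50000 nM, which is a limit of the assay and not a number.
Compound 2, `O=C(NCCCCl)Oc1ccc(Cl)cc1C(=O)Nc1ccc(C(F)(F)F)cc1`, in this assay gives < 50000 nM, again a limit and not a number.

Compound 2 therefore stands at the lower edge of what this assay can report: both values shown sit at the same limit, as the limit of < 50000 nM in this assay, at which 2 of the 2 values shown sit, records, so nothing distinguishes the two measured compounds in this assay.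

Compound 3, `O=C(NCCCCl)Oc1ccc(Cl)cc1C(=O)Nc1ccc(C(=O)c2ccccc2)cc1`, differs from compound 2 in one place: benzoyl in place of trifluoromethyl on an aromatic carbon. Going by the values given here, the change leaves the shared core untouched, and no measured pair shows what such a swap does in this assay. With both known values sitting at the limit, the step from compound 2 to compound 3 cannot be read from data; the expectation is that compound 3 also stays at or under the limit, so no step beyond the scatter can be expected to show, a step that the limit leaves unreadable from compound 2 to compound 3.

For compound 3 the estimated value in this assay is 20000 nM, expected to fall between 4000 nM and 50000 nM.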

Compound 3, solubility: < 50000 nM
Compound 3: a limit, no number; the forecaster's own chance of this, stated with the estimate: 80%; the middle value lies beyond the limit too.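

No step to compound 3 from compound 1 or compound 2 can be read, because all the results shown are limits of the assay and not numbers: the limit of < 50000 nM in this assay, at which 3 of the 3 values shown sit.

The compounds shown leave open how the three truly compare in this assay, and so whether benzoyl in place of trifluoromethyl on an aromatic carbon makes any difference there.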